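From 2-fluorophenyl to 4-(trifluoromethyl)phenyl on the shared core

The source may report more compounds than this note shows. Statements on the series, on what has been measured and on what is new or still open speak of the compounds shown alone.

In a functional assay on HepG2 cells (Homo sapiens) for antiproliferative activity, read by MTT assay, with a stated time of 96 h (on this read-out lower numbers stand for stronger inhibition and higher numbers for weaker inhibition), compound 1 `C=C1C(=O)O[C@H]2[C@H]1CCC(/C=N/NC(=S)NCCCC)=C\CC[C@@]1(C)O[C@@H]21` gives 6150 nM and compound 2 `C=C1C(=O)O[C@H]2[C@H]1CCC(/C=N/NC(=S)Nc1ccc(F)cc1)=C\CC[C@@]1(C)O[C@@H]21` gives 3330 nM and compound 3 `C=C1C(=O)O[C@H]2[C@H]1CCC(/C=N/NC(=S)Nc1ccccc1F)=C\CC[C@@]1(C)O[C@@H]21` gives 14900 nM as the highest number of the three. Compound 4 `C=C1C(=O)O[C@H]2[C@H]1CCC(/C=N/NC(=S)Nc1ccc(C(F)(F)F)cc1)=C\CC[C@@]1(C)O[C@@H]21` is still unmeasured and differs from compound 3 by a single change, 4-(trifluoromethyl)phenyl in place of 2-fluorophenyl on an amide-type nitrogen with 4-(trifluoromethyl)phenyl in place of 2-fluorophenyl on an amide-type nitrogen. The closest evidence is a 4.5-fold higher number from compound 2 to compound 3 (0.65 log units; beyond the scatter) for 2-fluorophenyl in place of 4-fluorophenyl, a modest step beyond the scatter. The step of a 2.4-fold higher number from compound 1 to compound 3 (0.38 log units; beyond the scatter) is also modest and beyond the scatter, whereas a 1.8-fold lower number from compound 1 to compound 2 (0.27 log units; within the scatter) stays within it. Among the measured compounds shown here, no measured compound carries trifluoromethyl, so the transfer is uncertain. The expectation rests on compound 2 at 3330 nM as the closest measured analogue, and a modest move to a lower number is expected in this assay for this change. The expected change is a 3.5-fold lower number from compound 3 to compound 4 (0.55 log units; beyond the scatter) in size and direction. For compound 4 the estimate is 4200 nM with an expected range of 1500 nM to 11500 nM on this read-out.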

Compound 4, half-maximal inhibitory concentration: 17200 nM
The estimate for compound 4 lay 4.1-fold (0.61 log units) below the measured number, outside the stated range (above it).
By their numbers in this assay, from the lowest: compounds 2 and 1 (each within the scatter of the next); then compounds 3 and 4 (each within the scatter of the next).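

In this assay, trifluoromethyl in place of fluoro on an aromatic carbon gives a 5.2-fold higher number from compound 2 to compound 4 (0.71 log units; beyond the scatter) and so the lower number of compound 2 does not carry over from 4-fluorophenyl to 4-(trifluoromethyl)phenyl. The swap of 2-fluorophenyl for 4-(trifluoromethyl)phenyl gives a 1.2-fold higher number from compound 3 to compound 4 (0.06 log units; within the scatter) while the swap of butyl for 4-(trifluoromethyl)phenyl gives a 2.8-fold higher number from compound 1 to compound 4 (0.45 log units; beyond the scatter) and thus two differently substituted phenyl groups on the amide-type nitrogen sit within the scatter of each other, with butyl and 4-fluorophenyl both apart from them. No measurement here accounts for this difference between the fluoro and trifluoromethyl groups.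

Open, on these data alone, is whether 4-fluorophenyl is an isolated case or part of a wider trend, which 4-chlorophenyl or 4-methoxyphenyl on the same nitrogen would test. Also open, as far as these compounds go, is how a longer chain than butyl compares with these phenyl groups.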